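A Second Methyl on the Core of Compound 1

The source may hold more compounds than are shown below. What is called first, only, known or untested is meant among the compounds shown, and "the series" means these compounds.

Compound 1 `CC1CN(C(=O)Nc2cc(F)c(F)c(F)c2)Cc2c(N3CC(C#N)CC3=O)cnn21` was tested in a toxicity assay on HepG2 2.2.15 cells (Homo sapiens) for cytotoxicity, read by CellTiter-Glo (a lower number here means that less compound is tolerated, a higher number that more compound is tolerated), where compound 1 gives 115000 nM. Compound 2 `O=C1CC(Oc2ncc(F)cn2)CN1c1cnn2c1CN(C(=O)Nc1cc(F)c(F)c(F)c1)C(C1CC1)C2` gives 96200 nM in the same assay, a number within the usual scatter of that of compound 1. Compound 3 `C[C@H]1Cn2ncc(N3CC(c4ccccc4)CC3=O)c2CN1C(=O)Nc1cc(F)c(F)c(F)c1` gives 12800 nM, so compound 1 stands highest of the three numbers, and only compound 3 falls clearly beneath it. Compound 4 `CC1(C)CN(C(=O)Nc2cc(F)c(F)c(F)c2)Cc2c(N3CC(C#N)CC3=O)cnn21` has not yet been measured. It differs from compound 1 by methyl in place of hydrogen on a saturated ring carbon. A change this small, with no comparable step among the measured compounds, gives no reason to expect a step beyond the scatter in either direction. The expected value of compound 4 in this assay is therefore 100000 nM, with a likely range from 50000 nM to 200000 nM. This expectation amounts to a step of a 1.2-fold lower number from compound 1 to compound 4 (0.06 log units; within the scatter).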

Compound 4, half-maximal cytotoxic concentration: > 200000 nM
Compound 4 ended at the assay's limit; the forecaster's own chance of this, stated with the estimate: 15%; at least 2.0-fold (0.30 log units) between middle value and limit.
By their numbers in this assay, from the lowest: compound 3; then compounds 2 and 1 (each within the scatter of the next). At a limit, above all of these: compound 4.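

In this assay, the result for compound 4 is a limit of the assay and not a number: the limit of > 200000 nM in this assay, at which 1 of the 4 values shown sits. Methyl in place of hydrogen on this saturated ring carbon gives an at least 1.7-fold higher number from compound 1 to compound 4 (0.24 log units; that floor lies within the scatter), so the true size of the step remains unknown. Even so, this position takes the added methyl with no fall in the tolerated concentration, something no earlier compound could show.

As far as these compounds go, whether a longer chain such as ethyl, or an amine, on this ring carbon would keep the number this high remains open.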